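Swapping methyl for chloro on the ester-bearing ring

The compounds below may be only part of what the source reports. "The series", "measured", "known", "first", "only" and "open" are said of these compounds alone.

Measured so far:
compound 1 `COC(=O)c1cc(Cl)ccc1OC(=O)COc1cc(O)c2c(=O)cc(-c3ccccc3)oc2c1` gives 3740 nM
compound 2 `COC(=O)c1ccc(C)cc1OC(=O)COc1cc(O)c2c(=O)cc(-c3ccccc3)oc2c1` gives 31100 nM
compound 3 `COC(=O)c1cccc(OC)c1OC(=O)COc1cc(O)c2c(=O)cc(-c3ccccc3)oc2c1` gives 36800 nM

All three share the same core and differ only in the ester-bearing ring, which is judged in a functional assay on cells (T-cell, Mus musculus, strain BALB/c) for inhibition, read by MTT assay, with a stated time of 72 h; a lower number here means a stronger inhibitor, a higher number a weaker inhibitor. On these numbers compound 2 stands second highest of the three, close to compound 3 and far from compound 1, which gives the lowest number.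

Compound 4 `COC(=O)c1ccc(Cl)cc1OC(=O)COc1cc(O)c2c(=O)cc(-c3ccccc3)oc2c1` is not yet measured. It differs from compound 2 by chloro in place of methyl on an aromatic carbon. Within the data shown here, the one measured step that speaks to this is an 8.3-fold higher number from compound 1 to compound 2 (0.92 log units; beyond the scatter), where a chloro-bearing ring was replaced by a methyl-bearing ring and the number rose. That step changes both the group and its place, so it is only a partial guide. Still, putting chloro back in, now at the place of the methyl, is expected to move the number down, by about a 3.5-fold lower number from compound 2 to compound 4 (0.54 log units; beyond the scatter). Compound 4 is therefore expected to give 9000 nM, within a range of 3000 nM to 30000 nM.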

Compound 4, half-maximal inhibitory concentration: 12400 nM
Compound 4: middle estimate off by 1.4-fold (0.14 log units), on the low side; the measured number falls inside the stated range.
By their numbers in this assay, from the lowest: compound 1; then compound 4; then compounds 2 and 3 (each within the scatter of the next).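

At the ring carbon meta to a large group and para to a methoxycarbonyl group, chloro in place of methyl gives a 2.5-fold lower number from compound 2 to compound 4 (0.40 log units; beyond the scatter) in this assay, so the swap now has a size of its own, free of any change of place. Keeping chloro while changing its place, with 5-chloro-2-(methoxycarbonyl)phenyl in place of 4-chloro-2-(methoxycarbonyl)phenyl, gives a 3.3-fold higher number from compound 1 to compound 4 (0.52 log units; beyond the scatter) and shows that the place of the chloro also counts. No measurement on hand explains either step.

Going by these compounds, only chloro and methyl are compared at this ring carbon, so the effect of an amine, a carboxylic acid or a longer chain such as propyl there stays open. Also open, on these data alone, is how methyl would fare at the place the chloro holds in compound 1, which would show whether the gain from chloro holds at both places.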